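Removing the Fluoro from a Biaryl Thiophene Amidine

The source may report more compounds than this note shows. Statements on the series, on what has been measured and on what is new or still open speak of the compounds shown alone.

Three amidine-bearing biaryl thiophenes were measured in a functional assay on COLO 205 cells (Homo sapiens) for inhibition, read by sulforhodamine B assay, with a stated time of 48 h; a lower number here means a stronger inhibitor of growth, a higher number a weaker inhibitor of growth. Compound 1 `COc1cc(OC)cc(-c2ccc(-c3ccc(C(=N)N)c(F)c3)s2)c1` gave 208 nM. Compound 2 `N=C(N)c1ccc(-c2ccc(-c3ccc(Cl)cc3)s2)cc1F` gave 200 nM, and compound 3 `N=C(N)c1ccc(-c2ccc(-c3ccc(Cl)cc3)s2)cc1` gave 203 nM. Compound 2 and compound 3 differ by hydrogen in place of fluoro on an aromatic carbon, and this step gave a 1.0-fold higher number from compound 2 to compound 3 (0.01 log units; within the scatter). The difference between the core of compound 1 and the core of compound 2 is not broken down here.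

Compound 4 `COc1cc(OC)cc(-c2ccc(-c3ccc(C(=N)N)cc3)s2)c1` has not been measured. It differs from compound 1 by hydrogen in place of fluoro on an aromatic carbon, the same change as from compound 2 to compound 3. Because a 1.0-fold higher number from compound 2 to compound 3 (0.01 log units; within the scatter) lay within the scatter, the step of a 1.0-fold higher number from compound 1 to compound 4 (0.00 log units; within the scatter) is expected to be of like size. In this assay compound 4 is therefore estimated at 210 nM, with a range from 100 nM to 430 nM.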

Compound 4, concentration for 50% growth inhibition: 1330 nM
Compound 4: middle estimate off by 6.3-fold (0.80 log units), on the low side, outside the stated range (above it).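

Hydrogen in place of fluoro did not carry over unchanged between the two cores in this assay: the same change on two cores in this assay, a 1.0-fold higher number (0.01 log units; within the scatter) from compound 2 to compound 3 and a 6.4-fold higher number (0.81 log units; beyond the scatter) from compound 1 to compound 4, 6.3-fold (0.80 log units) apart, beyond the scatter of two such steps. The larger step, a 6.4-fold higher number from compound 1 to compound 4 (0.81 log units; beyond the scatter), shows that the result on one core did not predict the result on the other. These two pairs do not show which part of the cores sets this difference or what lies behind it, and they give no rule for the wider series.

The compounds shown leave open whether a methyl or a hydroxyl group on that same aromatic carbon would follow fluoro or hydrogen on each core. They also leave open how the change behaves on cores carrying other groups, such as an amine, in the far aryl ring.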